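A few compounds are considered here, and "the series" means these few. Any claim that something is new, unique, unknown or untested is made for them only; others in the source may bear on it.

Compound 1 `CN1CCN(c2ccc3nc(-c4cccc5ccccc45)c(-c4ccncc4)n3n2)CC1` gives 880 nM in an assay on Sf9 cells for inhibition of receptor-interacting serine/threonine-protein kinase 3 (Homo sapiens), read by luminescence and 33P incorporation, with a stated time of 30 min, in the presence of a further agent that is not named here; on this read-out higher numbers stand for weaker inhibition and lower numbers for stronger inhibition.
Compound 2 `CN1CCN(c2ccc3nc(-c4cccc5c4OCCO5)c(-c4ccncc4)n3n2)CC1` gives only a limit of this assay, > 10000 nM.

Compound 2 thus stands at the limit of this assay, with only a range and no number, as recorded in the limit of > 10000 nM in this assay, at which 1 of the 2 values shown sits. The step from compound 1 to compound 2 was an at least 11-fold higher number from compound 1 to compound 2 (1.05 log units; beyond the scatter). Compound 3 `CN1CCN(c2ccc3nc(-c4ccc5ncsc5c4)c(-c4ccncc4)n3n2)CC1` differs from compound 2 in one place: 1,3-benzothiazol-6-yl in place of 2,3-dihydro-1,4-benzodioxin-5-yl on an aromatic carbon. Within the data shown here, only that one measured step bears on this change, and it shows how far the number can move when the group at this position of the shared core is exchanged. The new group, 1,3-benzothiazol-6-yl, contains two aromatic rings, as naphthalen-1-yl in compound 1 does, so the step of an at least 4.0-fold lower number from compound 2 to compound 3 (0.60 log units; beyond the scatter) is expected to turn back toward a measurable number. Compound 3 is therefore estimated at 2500 nM, within a range from 500 nM to 10000 nM.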

Compound 3, half-maximal inhibitory concentration: > 10000 nM
Compound 3 was reported as a limit (the forecaster's own chance of this, stated with the estimate: 30%); at least 4.0-fold (0.60 log units) between middle value and limit.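

Two aromatic rings in the group at this position were not enough to give a measurable number: 1,3-benzothiazol-6-yl has them, as naphthalen-1-yl does, yet the exchange gives an at least 11-fold higher number from compound 1 to compound 3 (1.05 log units; beyond the scatter). Among the three compounds, only compound 1 gives a number in this assay, while compound 2 and compound 3, with two different replacement groups, both stop at an assay limit: the limit of > 10000 nM in this assay, at which 2 of the 3 values shown sit. The step from compound 2 to compound 3 cannot be read, as both values are limits.

Going by these compounds, it remains open how far compound 2 and compound 3 lie beyond that limit, so the two groups cannot be ranked. On these data alone, it is also open whether a plain phenyl, or a naphthalen-1-yl carrying an amine, at this position of the shared core would give a measurable number.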